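This account rests on a few compounds, and the source may have more. Where it says the series, first, only, none or still open, it means among the compounds named here.

Compound 1 `C/C(=C\c1ccc(C(=O)Oc2ccc(C(=N)N)cc2)cc1)C(=O)N(CC(=O)O)C1CCCCC1`: in an in vitro ADME assay on a cell-free system (plasma) for pharmacokinetics (on this read-out higher numbers stand for a longer-lived compound and lower numbers for a shorter-lived compound), compound 1 gives > 1 h, which is a limit of the assay rather than a number.
Compound 2 `C/C(=C\c1ccc(C(=O)Oc2ccc(C(=N)N)cc2)cc1)C(=O)N(CC(=O)O)C1CCCC1`: in this assay compound 2 gives 0.383 h.
Compound 3 `C=CCN(CCCC(=O)OCC)C(=O)/C(C)=C/c1ccc(C(=O)Oc2ccc(C(=N)N)cc2)cc1`: in this assay compound 3 gives < 0.0167 h, again a limit of the assay rather than a number.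

Compound 3 sits at the limit of < 0.0167 h in this assay, at which 1 of the 3 values shown sits, the short-lived end of what the assay reports. Compound 1, by contrast, sits at the limit of > 1 h in this assay, at which 1 of the 3 values shown sits. Compound 4 `C=CCN(CCC(=O)OCC)C(=O)/C(C)=C/c1ccc(C(=O)Oc2ccc(C(=N)N)cc2)cc1` differs from compound 3 by ethoxycarbonyl in place of (ethoxycarbonyl)methyl on a saturated chain carbon, two bonds along the chain from an amide-type nitrogen. For the measured compounds named here, the one measured step, an at least 2.6-fold lower number from compound 1 to compound 2 (0.41 log units; beyond the scatter), concerns the ring carried on the amide-type nitrogen and not the ester-bearing chain, so it gives no direct guide to the present change, and no measured pair shows a shortening of this chain. With compound 3 already at the limit, compound 4 is expected to remain short-lived, the step that the limit leaves unreadable from compound 3 to compound 4 being an estimate without a measured counterpart. Compound 4 is therefore estimated at 0.012 h, within 0.003 h to 0.06 h, with a fair chance that the assay again reports only a limit.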

Compound 4, half-life: < 0.0167 h
Compound 4 gave a limit, no number; the forecaster's own chance of this, stated with the estimate: 65%; the middle value lies beyond the limit too.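

Shortening the chain from 3-(ethoxycarbonyl)propyl to 2-(ethoxycarbonyl)ethyl leaves compound 4 at the same limit of the assay as compound 3, a limit and not a number: the limit of < 0.0167 h in this assay, at which 2 of the 4 values shown sit. The step between these two compounds cannot be read, so neither chain length can be placed ahead of the other. For the compounds shown here, exchanging the whole substituent on the amide nitrogen for the one in compound 4, which carries an ethyl ester instead of the carboxymethyl group, gives an at least 22-fold lower number from compound 2 to compound 4 (1.36 log units; beyond the scatter) and an at least 59-fold lower number from compound 1 to compound 4 (1.77 log units; beyond the scatter) in this assay and so marks large steps, both well beyond the ring change alone.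

Going by these compounds, whether a free carboxylic acid on this same chain, in place of the ethyl ester, would lift the value off the limit remains open. Also open, on these data alone, is whether a cyclopentyl or cyclohexyl ring in place of the allyl group would do so while the ester stays.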